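Working notes: from compound 3 to compound 4

The compounds below may be only part of what the source reports. "The series", "measured", "known", "first", "only" and "open" are said of these compounds alone.

In an ADME assay on L1210/0 cells (Mus musculus) for cytotoxicity, with a stated time of 48 h (on this read-out lower numbers stand for stronger inhibition and higher numbers for weaker inhibition), compound 3 (`O=c1[nH]c(=O)n([C@H]2C[C@H](O)[C@@H](CO)O2)cc1C1SCCS1`) gives > 200000 nM as a limit and not a number. Compound 1 (`O=c1[nH]c(=O)n([C@H]2C[C@H](O)[C@@H](CO)O2)cc1C#CCCO`) gives > 200000 nM as a limit as well. Compound 2 (`CS(=O)(=O)Cc1cn([C@H]2C[C@H](O)[C@@H](CO)O2)c(=O)[nH]c1=O`) gives > 200000 nM as a limit too. Among the measured compounds shown here, the series therefore has no measured number so far, and all of its values sit at one ceiling (the limit of > 200000 nM in this assay, at which 3 of the 3 values shown sit) in this read-out.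

The next change is to compound 4 (`CCC#Cc1cn([C@H]2C[C@H](O)[C@@H](CO)O2)c(=O)[nH]c1=O`), described as a group of 4 heavy atoms (4 carbon; no ring) in place of a group of 5 heavy atoms (3 carbon, 2 sulfur; one five-membered non-aromatic ring with 2 hetero atoms), on an aromatic carbon and made on an aromatic carbon of the shared core. Three measured steps exchange the group at this carbon: a step that the two limits leave unreadable from compound 1 to compound 3 and a step that the two limits leave unreadable from compound 2 to compound 3 and a step that the two limits leave unreadable from compound 1 to compound 2 are the whole evidence. None of them has a readable size, so they give no direction of their own.

With compound 3 held at > 200000 nM as a limit, the working expectation is that but-1-yn-1-yl also stays at that limit in this assay and that no clear gain appears. The expected step is a number no higher from compound 3 to compound 4 (the limit leaves the size open) and it is estimated with low confidence. For compound 4 the estimated value is 200000 nM with an expected range of 60000 nM to 200000 nM on this read-out.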

Compound 4, half-maximal inhibitory concentration: > 200000 nM
Compound 4: only a limit was reported; the forecaster's own chance of this, stated with the estimate: 65%; the middle value sits exactly at the limit.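

Compound 4 gives > 200000 nM in this assay, a limit and not a number. No new step can be read, since compound 4 and each of compound 1, compound 2 and compound 3 are limits, and the series stays at one ceiling: the limit of > 200000 nM in this assay, at which 4 of the 4 values shown sit.

The compounds shown leave open whether any group at this aromatic carbon gives a measurable value, and how these four compounds rank.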